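Swapping the piperazine side group on a shared oxazolidinone core

This account rests on a few compounds, and the source may have more. Where it says the series, first, only, none or still open, it means among the compounds named here.

Measured so far:
- Compound 1 `CN1CCN(C[C@H]2CN(c3ccc(-n4cc(-c5ccccn5)cn4)c(F)c3)C(=O)O2)CC1`: in an ADME assay on L02 cells (Homo sapiens) for cytotoxicity, read by MTT assay, with a stated time of 48 h (on this read-out higher numbers stand for weaker inhibition and lower numbers for stronger inhibition), compound 1 gives 70 ug/mL
- Compound 2 `CS(=O)(=O)NC[C@H]1CN(c2ccc(-n3cc(-c4ccccn4)cn3)c(F)c2)C(=O)O1`: compound 2 gives only a limit of the assay, > 400 ug/mL
- Compound 3 `CN(C)S(=O)(=O)NC[C@H]1CN(c2ccc(-n3cc(-c4ccccn4)cn3)c(F)c2)C(=O)O1`: compound 3 gives 158 ug/mL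

Three compounds share one core and differ only in the group carried on a saturated chain carbon bound to a saturated ring carbon. Compound 1 stands lowest of the two numbers shown, meaning the strongest cytotoxicity here; its nearest neighbour is compound 3, and a 2.3-fold higher number from compound 1 to compound 3 (0.35 log units; beyond the scatter). Compound 2 reached only the limit of this assay (the limit of > 400 ug/mL in this assay, at which 1 of the 3 values shown sits), and an at least 5.7-fold higher number from compound 1 to compound 2 (0.75 log units; beyond the scatter). Between the two replacements, an at least 2.5-fold lower number from compound 2 to compound 3 (0.40 log units; beyond the scatter).

Compound 4 `COC(=O)NC[C@H]1CN(c2ccc(-n3cc(-c4ccccn4)cn3)c(F)c2)C(=O)O1` is not yet measured. It differs from compound 1 as follows: (methoxycarbonyl)amino in place of 4-methylpiperazin-1-yl on a saturated chain carbon bound to a saturated ring carbon. Both measured steps away from compound 1 exchange the same 4-methylpiperazin-1-yl group at the same place, and both gave a higher number, one modest and one at least modest. The step to compound 4 is expected to go the same way, with a clear rise in the number: a 3.6-fold higher number from compound 1 to compound 4 (0.55 log units; beyond the scatter). Compound 4 is therefore estimated at 250 ug/mL, most likely between 100 ug/mL and 600 ug/mL, with a fair chance that the assay again reports only a limit.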

Compound 4, half-maximal inhibitory concentration: 71 ug/mL
Compound 4: the middle estimate sits 3.5-fold (0.55 log units) above what was measured; the measured number lies below the stated range.
By their numbers in this assay, from the lowest: compounds 1 and 4 (each within the scatter of the next); then compound 3. At a limit, above all of these: compound 2.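

Exchanging 4-methylpiperazin-1-yl does not by itself separate a compound from compound 1 in this assay, as the change to (methoxycarbonyl)amino shows: a 1.0-fold higher number from compound 1 to compound 4 (0.01 log units; within the scatter), so compound 4 goes against the trend that the two earlier exchanges suggested. At this place, the group on the amine nitrogen now matters, since methoxycarbonyl in place of dimethylsulfamoyl gives a 2.2-fold lower number from compound 3 to compound 4 (0.35 log units; beyond the scatter), and methoxycarbonyl in place of methylsulfonyl gives an at least 5.6-fold lower number from compound 2 to compound 4 (0.75 log units; beyond the scatter). The value of compound 2 in that last step is a limit and not a number: the limit of > 400 ug/mL in this assay, at which 1 of the 4 values shown sits.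

Among the compounds shown here, with only one carbonyl-linked group and two sulfonyl-linked groups on this nitrogen, these compounds cannot show whether the gap follows the carbonyl or sulfonyl link in general or belongs to these particular groups, and an acetyl group or an ethoxycarbonyl group on the same nitrogen would test this. Going by these compounds, a free primary amine on the same saturated chain carbon also remains open, as it would show how the number responds when the amine nitrogen carries neither a carbonyl nor a sulfonyl group, and the data give no reason for any of these differences.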